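This account rests on a few compounds, and the source may have more. Where it says the series, first, only, none or still open, it means among the compounds named here.

Compound 2, with the structure `O=c1cc(-c2ccccc2)oc2cc(OCCCCNc3nc4c(F)cc(F)cc4s3)cc(O)c12`, is one of two compounds that have been tested in a functional assay on Ca-Ski cells (Homo sapiens) for cytotoxicity, read by sulforhodamine B assay, with a stated time of 48 h (on this read-out lower numbers stand for stronger inhibition and higher numbers for weaker inhibition), where compound 2 gives 10.8 ug/mL. The other, compound 1, with the structure `Cc1ccc2nc(NCCCCOc3cc(O)c4c(=O)cc(-c5ccccc5)oc4c3)sc2c1`, gives in this assay a value of 15.5 ug/mL. The step of a 1.4-fold lower number from compound 1 to compound 2 (0.16 log units; within the scatter) shows that the two numbers lie within the scatter of each other, so compound 2 cannot be called stronger or weaker than compound 1 on these data.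

Compound 3 has the structure `O=c1cc(-c2ccccc2)oc2cc(OCCCCNNc3nc4ccccc4s3)cc(O)c12`. It differs from compound 2 in one place: (1,3-benzothiazol-2-yl)amino in place of 4,6-difluoro-1,3-benzothiazol-2-yl on an amine nitrogen. Within the data shown here, no measured step covers this kind of change; the only step known, a 1.4-fold lower number from compound 1 to compound 2 (0.16 log units; within the scatter), swapped the substituents on the benzothiazole ring and stayed within the scatter. That step says nothing direct about inserting a second nitrogen into the linker, so the expectation can only rest on the observation that both measured compounds of this core fall close together in this assay. The number for compound 3 is therefore expected to stay near that of compound 2, with a step of a 1.2-fold higher number from compound 2 to compound 3 (0.08 log units; within the scatter) and no direction beyond the scatter. Compound 3 is estimated at 13 ug/mL, in the range 5 ug/mL to 35 ug/mL.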

Compound 3, half-maximal inhibitory concentration: 14.6 ug/mL
Compound 3: the middle estimate sits 1.1-fold (0.05 log units) below what was measured; the measured number falls inside the stated range.
By their numbers in this assay, from the lowest: compounds 2, 3 and 1 (each within the scatter of the next).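

On an amine nitrogen whose other neighbour is a saturated chain carbon, (1,3-benzothiazol-2-yl)amino in place of 4,6-difluoro-1,3-benzothiazol-2-yl gives a 1.4-fold higher number from compound 2 to compound 3 (0.13 log units; within the scatter) in this assay, and in place of 6-methyl-1,3-benzothiazol-2-yl it gives a 1.1-fold lower number from compound 1 to compound 3 (0.03 log units; within the scatter) in the same test. The earlier pair showed only that one substituted benzothiazole could replace another, whereas this change adds a second nitrogen to the link and removes the ring substituents, so the entering group has 1 hydrogen-bond donor and 3 hydrogen-bond acceptors against 0 and 2 for the 4,6-difluoro group. All three compounds still lie within the scatter of one another, so none of these groups can be ranked above another at this position.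

A plain 1,3-benzothiazol-2-yl group on the amine nitrogen would separate the effect of the second nitrogen from that of the ring substituents, while a carboxylic acid or a longer chain would test whether this position stays as tolerant with very different groups. Nothing available here explains why the three numbers stay so close together.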